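The compounds below may be only part of what the source reports. "The series", "measured", "known", "first", "only" and "open" are said of these compounds alone.

Of the compounds shown here, three sharing one core have been measured in a functional assay on A-375 cells (Homo sapiens) for cytotoxicity, read by MTT assay; on this read-out lower numbers stand for stronger inhibition and higher numbers for weaker inhibition. Compound 1 `O=S(=O)(NCCNc1nccc(-c2c(-c3cccc(F)c3)nc3sccn23)n1)c1ccc(Br)cc1` gives 13500 nM in this assay. Compound 2 `O=C(NCCNc1nccc(-c2c(-c3cccc(F)c3)nc3sccn23)n1)c1c(F)cccc1F` gives 2700 nM. Compound 3 `O=S(=O)(NCCNc1nccc(-c2c(-c3cccc(F)c3)nc3sccn23)n1)c1ccc(Cl)cc1` gives 18600 nM, which is the highest of the three numbers; compound 1 is nearest to it, and compound 2 is furthest. Among the measured compounds shown here, the one step that reached beyond the scatter in this assay is a 5.0-fold lower number from compound 1 to compound 2 (0.70 log units; beyond the scatter), and its reverse, a 6.9-fold higher number from compound 2 to compound 3 (0.84 log units; beyond the scatter), points the same way: a sulfonyl linker gives the higher number, a carbonyl linker the lower one.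

Compound 4 `O=C(NCCNc1nccc(-c2c(-c3cccc(F)c3)nc3sccn23)n1)c1ccc(C(F)(F)F)cc1` carries the change ((4-(trifluoromethyl)phenyl)carbonyl in place of (4-chlorophenyl)sulfonyl on an amine nitrogen). For the measured compounds named here, the step from sulfonyl to carbonyl is the part that the measured steps speak to, while the aromatic ring on the carbonyl is new and no measured step covers it. A modestly lower number is therefore expected for compound 4, estimated at 3500 nM with a range of 1200 nM to 10000 nM, which means a step of a 5.3-fold lower number from compound 3 to compound 4 (0.73 log units; beyond the scatter).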

Compound 4, half-maximal inhibitory concentration: 8710 nM
The estimate for compound 4 lay 2.5-fold (0.40 log units) below the measured number, within the range that was stated.
By their numbers in this assay, from the lowest: compound 2; then compounds 4, 1 and 3 (each within the scatter of the next, the first and the last beyond it).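

Moving from sulfonyl to carbonyl on the amine nitrogen does not lower the number by a set amount: there is a 2.1-fold lower number from compound 3 to compound 4 (0.33 log units; beyond the scatter), which only just passes the scatter, whereas a 1.5-fold lower number from compound 1 to compound 4 (0.19 log units; within the scatter) stays within it, so compound 1 goes against the earlier sulfonyl-versus-carbonyl pattern. The aromatic ring on the carbonyl also counts, since the change to 4-(trifluoromethyl)phenyl from 2,6-difluorophenyl on a carbonyl carbon gives a 3.2-fold higher number from compound 2 to compound 4 (0.51 log units; beyond the scatter) and so the carbonyl alone does not fix the number. Nothing available explains why these two rings differ.

Still open, as far as these compounds go, is whether 2,6-difluorophenyl on a sulfonyl would keep the lower number, which would separate the linker's contribution from the ring's. From the compounds shown here alone, how a saturated ring such as cyclohexyl or a piperidine on the carbonyl carbon would read also remains unknown.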